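Dropping Both Hydroxyls from a Chalcone Aryl Ketone

A few compounds are considered here, and "the series" means these few. Any claim that something is new, unique, unknown or untested is made for them only; others in the source may bear on it.

Of the compounds shown here, three sharing a trimethoxyphenyl chalcone core have been tested in a functional assay on HeLa cells (Homo sapiens) for inhibition, read by MTT assay, with a stated time of 72 h; a lower number here means a stronger inhibitor, a higher number a weaker inhibitor. Compound 1 `COc1cc(OC)c(OC)cc1/C=C/C(=O)c1cc(OC(C)=O)ccc1OC(C)=O` gives 57900 nM, compound 2 `COc1cc(OC)c(OC)cc1/C=C/C(=O)c1ccc(O)cc1O` gives 37600 nM, and compound 3 `COc1cc(OC)c(C(=O)/C=C/c2cc(OC)c(OC)cc2OC)c(OC)c1` gives 108000 nM. Compound 2 shows the lowest number of the three; its gap to compound 1 lies within the scatter, while compound 3 sits beyond it.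

Compound 4 `COc1cc(OC)c(OC)cc1/C=C/C(=O)c1ccccc1` differs from compound 2 in one place: phenyl in place of 2,4-dihydroxyphenyl on a carbonyl carbon. Compound 1, which also lacks free hydroxyls, sits close to compound 2, so little shift is expected. Compound 4 is estimated at 65000 nM (range 25000 nM to 160000 nM) in this assay. This expected step of a 1.7-fold higher number from compound 2 to compound 4 (0.24 log units; within the scatter) would be a modest weakening, near the edge of the scatter.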

Compound 4, half-maximal inhibitory concentration: > 150000 nM
Compound 4 gave a limit, no number (the forecaster's own chance of this, stated with the estimate: 10%); middle value at least 2.3-fold (0.36 log units) from the limit.
By their numbers in this assay, from the lowest: compounds 2, 1 and 3 (each within the scatter of the next, the first and the last beyond it). At a limit, above all of these: compound 4.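

Putting phenyl in place of 2,4-dihydroxyphenyl on a carbonyl carbon gives an at least 3.9-fold higher number from compound 2 to compound 4 (0.60 log units; beyond the scatter). Within the data shown here, this is the first change in one place in this set, and it shows that removing both hydroxyls on this ring weakens the compound beyond the scatter. Compound 4 gives > 150000 nM, which is a limit and not a number, and the full size of the step stays unknown because the reading stops there: the limit of > 150000 nM in this assay, at which 1 of the 4 values shown sits.

Going by these compounds, it remains open whether a phenyl carrying a single hydroxyl would behave like compound 2 or like compound 4. On these data alone, it is also open whether an amine or a carboxylic acid on this ring could take the place of the hydroxyls.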